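Allyl and propyl on the amine of compound 3

This account rests on a few compounds, and the source may have more. Where it says the series, first, only, none or still open, it means among the compounds named here.

Compound 1 `CCN(Cc1c(C(F)(F)F)nc2n(-c3c(C)cc(C)cc3C)c(Cl)cn12)CC1CC1`: 9 nM
Compound 2 `CCCCN(CC)Cc1c(C(F)(F)F)nc2n(-c3c(C)cc(C)cc3C)c(Cl)cn12`: 78 nM
Compound 3 `CCCCN(C)Cc1c(C(F)(F)F)nc2n(-c3c(C)cc(C)cc3C)c(Cl)cn12`: 310 nM

In an assay on cells for displacement of a labelled ligand from corticotropin-releasing factor receptor 1 (Homo sapiens), with a stated time of 100 min (a higher number here means a weaker inhibitor, a lower number a stronger inhibitor), compound 3 stands highest of the three, beyond the scatter from both others. Compound 4 `C=CCN(CCC)Cc1c(C(F)(F)F)nc2n(-c3c(C)cc(C)cc3C)c(Cl)cn12` differs from it by allyl(propyl)amino in place of butyl(methyl)amino on a saturated chain carbon bound to an aromatic carbon. Among the measured compounds shown here, two measured steps bear on this change. Lengthening the smaller group on the amine nitrogen went a 4.0-fold higher number from compound 2 to compound 3 (0.60 log units; beyond the scatter) in the other direction, and swapping both groups gave a 34-fold higher number from compound 1 to compound 3 (1.54 log units; beyond the scatter). Compound 4 carries two larger groups than compound 3, so in this assay a lower number is expected, plausibly between the values of compound 2 and compound 1. The expected step is a 12-fold lower number from compound 3 to compound 4 (1.09 log units; beyond the scatter), giving an estimated 25 nM for compound 4, within a range of 6 nM to 100 nM.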

Compound 4, inhibition constant: 4.5 nM
Estimate against measurement, compound 4: 5.6-fold (0.74 log units) above; the measured number lies below the stated range.
By their numbers in this assay, from the lowest: compounds 4 and 1 (each within the scatter of the next); then compound 2; then compound 3.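

In this assay, among the compounds shown here, the groups on the amine nitrogen matter more than the earlier compounds showed: allyl(propyl)amino in place of butyl(methyl)amino gives a 69-fold lower number from compound 3 to compound 4 (1.84 log units; beyond the scatter) and in place of butyl(ethyl)amino gives a 17-fold lower number from compound 2 to compound 4 (1.24 log units; beyond the scatter). Replacing (cyclopropylmethyl)(ethyl)amino gives a 2.0-fold lower number from compound 1 to compound 4 (0.30 log units; within the scatter) so two different pairs of groups reach the same level. Nothing measured here explains these differences. As far as these compounds go, whether the double bond of the allyl group matters remains open: a dipropylamino group would separate its contribution from that of chain length, and dibutylamino would test still longer chains.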